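Methylsulfonyl for cyano on the pendant phenyl ring

The source may hold more compounds than are shown below. What is called first, only, known or untested is meant among the compounds shown, and "the series" means these compounds.

Compounds with numbers so far in a functional assay on A549 cells (Homo sapiens) for antiproliferative activity, read by MTT assay, with a stated time of 72 h; a lower number here means a stronger inhibitor, a higher number a weaker inhibitor:
compound 1 `Clc1ccc(C2CC(c3ccc(N4CCCCC4)cc3)=NN2c2nc(-c3ccccc3)cs2)cc1`, compound 1 gives 64200 nM
compound 2 `Fc1ccc(-c2csc(N3N=C(c4ccc(N5CCCCC5)cc4)CC3c3ccc(Cl)cc3)n2)cc1`, compound 2 gives 70200 nM
compound 3 `N#Cc1ccc(-c2csc(N3N=C(c4ccc(N5CCCCC5)cc4)CC3c3ccc(Cl)cc3)n2)cc1`, compound 3 gives 11200 nM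

Compound 3 holds the lowest number of the three; its steps to compound 1 and compound 2 both lie beyond the scatter. The two steps on the same ring show what substitution there has done so far: a 1.1-fold higher number from compound 1 to compound 2 (0.04 log units; within the scatter), while a 5.7-fold lower number from compound 1 to compound 3 (0.76 log units; beyond the scatter) and a 6.3-fold lower number from compound 2 to compound 3 (0.80 log units; beyond the scatter). So one replacement at this carbon left the number unmoved and another lowered it modestly.

Compound 4 `CS(=O)(=O)c1ccc(-c2csc(N3N=C(c4ccc(N5CCCCC5)cc4)CC3c3ccc(Cl)cc3)n2)cc1` is not yet measured. It differs from compound 3 as follows: methylsulfonyl in place of cyano on an aromatic carbon. For the measured compounds named here, no measured pair shows methylsulfonyl at this place, so the two steps above only set the scale of what a change here has produced, from no movement to a modest drop. Nothing here points clearly one way, and the expected step is a 1.3-fold higher number from compound 3 to compound 4 (0.13 log units; within the scatter), within the scatter, with wide uncertainty. The estimate for compound 4 in this assay is 15000 nM, with a range from 4000 nM to 50000 nM.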

Compound 4, half-maximal inhibitory concentration: > 100000 nM
Compound 4 was reported as a limit (the forecaster's own chance of this, stated with the estimate: 10%); middle value at least 6.6-fold (0.82 log units) from the limit.
By their numbers in this assay, from the lowest: compound 3; then compounds 1 and 2 (each within the scatter of the next). At a limit, above all of these: compound 4.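

In this assay compound 4 is reported only as a limit, not a number: the limit of > 100000 nM in this assay, at which 1 of the 4 values shown sits.

Methylsulfonyl therefore does not keep what cyano gave at this carbon, with an at least 8.9-fold higher number from compound 3 to compound 4 (0.95 log units; beyond the scatter), so the position is sensitive to which group replaces cyano and not merely to whether the hydrogen is replaced. The other two steps, an at least 1.4-fold higher number from compound 2 to compound 4 (0.15 log units; that floor lies within the scatter) and an at least 1.5-fold higher number from compound 1 to compound 4 (0.19 log units; that floor lies within the scatter), set no order, since each floor lies within the scatter.

The compounds shown do not tell how far past the limit compound 4 lies, nor what separates cyano from methylsulfonyl here. Also open, as far as these compounds go, is whether a carboxylic acid, a primary amide or a methoxy group on this carbon would read closer to compound 3 or to compound 4.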